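The source may hold more compounds than are shown below. What is called first, only, known or untested is meant among the compounds shown, and "the series" means these compounds.

Compound 2 `C=CC(=O)Nc1cccc(NC(=O)CSc2nc(Nc3cccc(C)c3)c3ccccc3n2)c1` is one of two measured members of a small set built on a shared core. In a functional assay on NCI-H1975 cells (Homo sapiens) for inhibition, read by MTT assay, with a stated time of 72 h (a higher number here means a weaker inhibitor, a lower number a stronger inhibitor), compound 2 gives 12100 nM. Its only measured neighbour, compound 1 `C=CC(=O)Nc1cccc(NC(=O)CSc2nc(Nc3cccc(Br)c3)c3ccccc3n2)c1`, gives 12100 nM in this assay, so compound 2 stands level with compound 1 at the digits shown, and the one recorded step, no change at the digits printed from compound 1 to compound 2 (within the scatter), lies within the scatter of repeated measurements.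

Compound 3 `C=CC(=O)Nc1cccc(NC(=O)CSc2nc(Nc3ccc(Cl)c(Cl)c3)c3ccccc3n2)c1` has not yet been measured in this assay. It differs from compound 2 by 3,4-dichlorophenyl in place of 3-methylphenyl on a nitrogen on an aromatic ring. Among the measured compounds shown here, only one measured step bears on this change, the swap of one substituent for another on that same aromatic ring, no change at the digits printed from compound 1 to compound 2 (within the scatter), and it produced no movement beyond the scatter. For the measured compounds named here, with both measured compounds sitting at the same weak level and the single comparable step flat, no change beyond the scatter is expected here, and the step anticipated in this assay is a 1.2-fold lower number from compound 2 to compound 3 (0.08 log units; within the scatter). Compound 3 is therefore estimated at 10000 nM, with a range from 4000 nM to 30000 nM.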

Compound 3, half-maximal inhibitory concentration: 19100 nM
For compound 3 the middle estimate is 1.9-fold (0.28 log units) below the measured one, and the stated range covers the measured number.
By their numbers in this assay, from the lowest: compounds 1, 2 and 3 (each within the scatter of the next).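

In this assay, 3,4-dichlorophenyl in place of 3-methylphenyl on a nitrogen on an aromatic ring gives a 1.6-fold higher number from compound 2 to compound 3 (0.20 log units; within the scatter), and the same group in place of 3-bromophenyl gives a 1.6-fold higher number from compound 1 to compound 3 (0.20 log units; within the scatter), so neither step leaves the scatter. The earlier pair had shown only that one single substituent on this ring could replace another without a change at the digits printed; these two steps add that a ring carrying two chlorine atoms also stays within the scatter of both earlier compounds, so that all three cannot be told apart in this read-out and the change at this position has so far produced no separable effect. Nothing measured here offers an explanation for these readings, whether for the level the three compounds share or for the small steps among them.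

The compounds shown leave open whether an amine, a carboxylic acid or a longer chain on this aromatic ring would carry the number beyond the scatter, as all three carry only halogen or methyl there. They also leave open whether a change elsewhere on the shared core, such as replacing the acrylamide, would move the number more than any change at this position has.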